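A few compounds are considered here, and "the series" means these few. Any claim that something is new, unique, unknown or untested is made for them only; others in the source may bear on it.

Measured so far in a functional assay on EA.hy 926 cells (Homo sapiens) for cytotoxicity, read by MTT assay, with stated times of 24 h and 12 h, tested at 50 uM; a higher number here means a stronger effect of the compound at the concentration tested, a lower number a weaker effect:

Compound 1, `Cc1nc(C)c(C(=O)Oc2ccccc2/C=C/C(=O)O)nc1C`: compound 1 gives 64.9%.
Compound 2, `COc1ccc(OC(=O)c2nc(C)c(C)nc2C)c(/C=C/C(=O)O)c1`: compound 2 gives 62.9%.
Compound 3, `Cc1nc(C)c(C(=O)Oc2ccc(Cl)cc2/C=C/C(=O)O)nc1C`: compound 3 gives 23.7%.

All three share one core and differ only on an aromatic carbon, where compound 1 carries hydrogen, compound 2 methoxy and compound 3 chloro. Compound 3 stands lowest of the three numbers. The two steps leading to it are large: a number 41.2 percentage points lower from compound 1 to compound 3 (beyond the scatter) and a number 39.2 percentage points lower from compound 2 to compound 3 (beyond the scatter). By contrast, a number 2 percentage points lower from compound 1 to compound 2 (within the scatter), so the methoxy for hydrogen exchange makes no real difference.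

Compound 4, `CCOC(=O)/C=C/c1cc(Cl)ccc1OC(=O)c1nc(C)c(C)nc1C`, keeps the chloro of compound 3 and changes a different part of the molecule: ethyl in place of hydrogen on an oxygen next to a carbonyl group. Within the data shown here, none of the measured steps touches this position; all of them concern the substituent on the aromatic carbon. Among the measured compounds shown here, there is therefore no measured step that bears on the exchange of hydrogen for ethyl on the acid oxygen, and no direction can be read from the data. The most defensible expectation is a value close to that of compound 3, with wide uncertainty on either side. Compound 4 is thus estimated to give about 30%, with a range from 12% to 58%. The expected step, a number 6.3 percentage points higher from compound 3 to compound 4 (within the scatter), lies within the scatter.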

Compound 4, a percentage reported as activity, at one concentration (the size of the read-out at that concentration, not a potency): 33.7%
Estimate against measurement, compound 4: 3.7 percentage points below, and the stated range covers the measured number.
By their numbers in this assay, from the lowest: compounds 3 and 4 (each within the scatter of the next); then compounds 2 and 1 (each within the scatter of the next).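

Among these compounds, the step at this position is the first measured one outside the aromatic carbon: in this assay, replacing hydrogen with ethyl on an oxygen next to a carbonyl group turns the carboxy group into an ethoxycarbonyl group, and the result is a number 10 percentage points higher from compound 3 to compound 4 (within the scatter). In this chloro-bearing pair, then, the low number seen with the free carboxy group does not depend on that hydrogen, since capping it with ethyl produces no difference that can be told from the scatter. Nothing at hand explains this outcome, and the result on its own gives no reason for it.

This single pair cannot show whether the same exchange would also leave the number within the scatter when the aromatic carbon carries hydrogen, as in compound 1, or methoxy, as in compound 2. It also leaves open what a longer chain such as butyl on the same oxygen would do, or an amide in place of the ester, so the tolerance seen with ethyl cannot yet be extended to other groups.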